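This account rests on a few compounds, and the source may have more. Where it says the series, first, only, none or still open, it means among the compounds named here.

Compound 1 `COCOC/C1=C/C[C@](C)(CCC=C(C)C)/C=C/[C@@H](OC(=O)C=C(C)C)[C@](C)(O)/C=C/C1=O`: 3250 nM
Compound 2 `CC(C)=CCC[C@]1(C)/C=C/[C@@H](OC(=O)C=C(C)C)[C@](C)(O)/C=C/C(=O)/C(C(=O)N(C)C)=C\C1`: 3670 nM

Both values come from a functional assay on SMMC-7721 cells (Homo sapiens) for antiproliferative activity, read by MTT assay, with a stated time of 48 h; on this read-out lower numbers stand for stronger inhibition and higher numbers for weaker inhibition. For the measured compounds named here, compound 2, at 3670 nM, cannot be separated from compound 1, as the one measured step, a 1.1-fold higher number from compound 1 to compound 2 (0.05 log units; within the scatter), lies within the scatter.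

Next in the series is compound 3 `CC(C)=CCC[C@]1(C)/C=C/[C@@H](OC(=O)C=C(C)C)[C@](C)(O)/C=C/C(=O)/C(C(=O)N2CCCC2)=C\C1`, which keeps the core of compound 2 and alters only the amide: pyrrolidin-1-yl in place of dimethylamino on a carbonyl carbon. Here, pyrrolidin-1-yl takes the place of dimethylamino on a carbonyl carbon. Going by the values given here, no measured step covers this exchange directly. The closest evidence is the replacement of the whole group on the double-bonded ring carbon, and that step, a 1.1-fold higher number from compound 1 to compound 2 (0.05 log units; within the scatter), stayed within the scatter. Two compounds make thin evidence, so the range is kept wide. The expected change is a 1.0-fold lower number from compound 2 to compound 3 (0.02 log units; within the scatter), with no shift in either direction beyond the scatter. Compound 3 is estimated at 3500 nM, with an expected range of 1500 nM to 8000 nM.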

Compound 3, half-maximal inhibitory concentration: 14900 nM
Compound 3: the middle estimate sits 4.3-fold (0.63 log units) below what was measured; the measured number lies above the stated range.
By their numbers in this assay, from the lowest: compounds 1 and 2 (each within the scatter of the next); then compound 3.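

Pyrrolidin-1-yl in place of dimethylamino on a carbonyl carbon gives a 4.1-fold higher number from compound 2 to compound 3 (0.61 log units; beyond the scatter) in this assay, so at this position the amine part of the amide can move the read-out beyond the scatter, which the earlier exchange on the double-bonded ring carbon did not do. Measured against the (methoxymethoxy)methyl group on that same carbon, the change reads a 4.6-fold higher number from compound 1 to compound 3 (0.66 log units; beyond the scatter), so the dimethylcarbamoyl result does not carry over to (pyrrolidin-1-yl)carbonyl. Nothing available offers an explanation for the weaker number of compound 3.

On these data alone, whether the ring itself or the added carbons go with this shift stays open, and an open-chain diethylamino amide would help separate the two. A morpholine amide or a methylamino amide, which keeps an amide hydrogen, would show how far this position extends beyond these two tertiary amides.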